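A few compounds are considered here, and "the series" means these few. Any claim that something is new, unique, unknown or untested is made for them only; others in the source may bear on it.

Measured compounds in a functional assay on DLD-1 cells (Homo sapiens) for antiproliferative activity, read by CellTiter-Glo, with a stated time of 72 h; on this read-out higher numbers stand for weaker inhibition and lower numbers for stronger inhibition:
compound 1, `CC1CCN(C2CCN(S(=O)(=O)c3cccc(N)c3)CC2)CC1`, where compound 1 gives 3400 nM;
compound 2, `CC1CCN(C2CCN(S(=O)(=O)c3cnc(Cl)s3)CC2)CC1`, where compound 2 gives 1800 nM;
compound 3, `Cc1ccc(S(=O)(=O)N2CCC(N3CCC(C)CC3)CC2)cc1C`, where compound 3 gives 24 nM.

Compound 1 stands at the highest number of the three in this assay. Its nearest neighbour is compound 2, reached by a 1.9-fold lower number from compound 1 to compound 2 (0.28 log units; within the scatter); its furthest is compound 3, reached by a 140-fold lower number from compound 1 to compound 3 (2.15 log units; beyond the scatter).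

Compound 4, `CC1CCN(C2CCN(S(=O)(=O)c3cccc(-c4ccc5ccccc5c4)c3)CC2)CC1`, differs from compound 1 by naphthalen-2-yl in place of amino on an aromatic carbon. For the measured compounds named here, no measured step introduces a naphthalenyl group, so the guidance is indirect. The step of a 140-fold lower number from compound 1 to compound 3 (2.15 log units; beyond the scatter) shows that exchanging the 3-aminophenyl group for the 3,4-dimethylphenyl group brings a large fall in the number, whereas a 1.9-fold lower number from compound 1 to compound 2 (0.28 log units; within the scatter) stays within the scatter. Since the amino group is again removed in compound 4, a fall beyond the scatter is expected in this assay, given as an 11-fold lower number from compound 1 to compound 4 (1.05 log units; beyond the scatter), though with wide uncertainty. Compound 4 is therefore estimated at 300 nM, with a range from 40 nM to 2500 nM.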

Compound 4, half-maximal inhibitory concentration: 2 nM
Estimate against measurement, compound 4: 150-fold (2.18 log units) above, outside the stated range (below it).
By their numbers in this assay, from the lowest: compound 4; then compound 3; then compounds 2 and 1 (each within the scatter of the next).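

In this assay, the aromatic carbon that carries amino in compound 1 accepts naphthalen-2-yl, with a 1700-fold lower number from compound 1 to compound 4 (3.23 log units; beyond the scatter), the largest step among those shown. The earlier steps shown here exchanged the whole aromatic group on the sulfonyl sulfur, whereas this one keeps that six-membered ring and changes only the group on it, so a change at this one position is enough to bring a large fall in the number. Nothing given here accounts for the size of this step.

The compounds shown do not separate the loss of amino from the arrival of naphthalen-2-yl. On these data alone, whether a single phenyl, a methoxy group or a carboxylic acid on the same aromatic carbon would give a number close to that of compound 4 remains open.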